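A Phenyl Swap at the Edge of Measurement

The source may report more compounds than this note shows. Statements on the series, on what has been measured and on what is new or still open speak of the compounds shown alone.

In an ADME assay on BJ cells (Homo sapiens) for cytotoxicity, read by CellTiter-Glo and resazurin assay, with a stated time of 72 h (a higher number here means that more compound is needed for the effect, a lower number that less compound is needed), compound 2 `CCOC(=O)CCCCCOc1cccc(CN(C(=O)c2ccc(-c3cccc(OC(F)(F)F)c3)cc2)C(C)C)c1` stands at > 26000 nM, which is a limit and not a number. Compound 1 `CCOC(=O)CCCCCOc1cccc(CN(C(=O)c2ccc(-c3ccc4cc[nH]c4c3)cc2)C(C)C)c1` gives > 26000 nM, which is also a limit. Going by the values given here, the only other value therefore offers no number against which to place compound 2. Among the compounds with values here, the one measured step, a step that the two limits leave unreadable from compound 1 to compound 2, puts 3-(trifluoromethoxy)phenyl in place of 1H-indol-6-yl on an aromatic carbon, and it has no readable size. The evidence so far amounts to the limit of > 26000 nM in this assay, at which 2 of the 2 values shown sit.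

Compound 3 `CCOC(=O)CCCCCOc1cccc(CN(C(=O)c2ccc(-c3cc(OC)ccc3F)cc2)C(C)C)c1` changes that same group again, with 2-fluoro-5-methoxyphenyl in place of 3-(trifluoromethoxy)phenyl, para to a large group: 2-fluoro-5-methoxyphenyl in place of 3-(trifluoromethoxy)phenyl on an aromatic carbon. The earlier exchange at this place, a step that the two limits leave unreadable from compound 1 to compound 2, gives no measured size to carry over, yet it shows no departure from the limit. No step beyond the scatter is therefore expected in this assay, and another limit is the likeliest report. The estimated step is a step that the limit leaves unreadable from compound 2 to compound 3, with no direction expected. For compound 3 the estimate is 28000 nM, with an expected range from 14000 nM to 52000 nM.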

Compound 3, half-maximal effective concentration: > 26000 nM
Compound 3 gave a limit, no number; the forecaster's own chance of this, stated with the estimate: 85%; the middle value is on the limit's open side.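

In this assay, going by these compounds alone, compound 3 gives > 26000 nM as a limit, and no step from compound 1 or compound 2 to compound 3 can be read. The compounds shown leave open where any of the three would reach its half-maximal effect, and whether the three groups differ at all in this assay. The record stands at one point: the limit of > 26000 nM in this assay, at which 3 of the 3 values shown sit.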